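This account rests on a few compounds, and the source may have more. Where it says the series, first, only, none or still open, it means among the compounds named here.

Measured compounds:
Compound 1 `CN(C)C12CC(c3ccccc3)C(CN(C(=O)CN3CCCCC3)C1)C(c1ccccc1)C2` gives 12100 nM in an ADME assay on L6 cells (Rattus norvegicus) for cytotoxicity, read by resazurin assay, with a stated time of 72 h; a higher number here means a weaker inhibitor, a lower number a stronger inhibitor.
Compound 2 `CN(C)C12CC(c3ccccc3)C(CN(C(=O)CCN3CCCCC3)C1)C(c1ccccc1)C2` gives 12400 nM in this assay.

Among the measured compounds shown here, compound 1 holds the lower of the two numbers recorded, but its nearest neighbour, compound 2, sits within the scatter of it, so the two cannot be told apart; the only measured step, a 1.0-fold higher number from compound 1 to compound 2 (0.01 log units; within the scatter), lengthens the piece attached to the carbonyl and changes nothing beyond the scatter.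

Compound 3 `CN1CCN(CCN2CC3C(c4ccccc4)CC(N(C)C)(CC3c3ccccc3)C2)CC1` is not yet measured. It keeps the shared core of compound 1 and differs in one place: 2-(4-methylpiperazin-1-yl)ethyl in place of ((piperidin-1-yl)methyl)carbonyl on an amine nitrogen in a ring. The carbonyl is gone, and the piece entering is a different chain and ring.

For the measured compounds named here, only the step from compound 1 to compound 2 bears on this, and it concerns the chain on the carbonyl side rather than the carbonyl itself, so it is a weak guide. With no measured change beyond the scatter anywhere in this set, the expected step of a 1.2-fold lower number from compound 1 to compound 3 (0.08 log units; within the scatter) is set close to none. Compound 3 is therefore estimated at 10000 nM, expected to fall between 3000 nM and 40000 nM.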

Compound 3, half-maximal inhibitory concentration: 5260 nM
For compound 3 the middle estimate is 1.9-fold (0.28 log units) above the measured one; the range from low to high includes it.
By their numbers in this assay, from the lowest: compound 3; then compounds 1 and 2 (each within the scatter of the next).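

In this assay this position on the amine nitrogen in a ring now shows that it can shift the number, since placing 2-(4-methylpiperazin-1-yl)ethyl there gives a 2.3-fold lower number from compound 1 to compound 3 (0.36 log units; beyond the scatter) and also a 2.4-fold lower number from compound 2 to compound 3 (0.37 log units; beyond the scatter) in a set that had so far shown no change beyond the scatter. Both steps are modest, yet they point the same way and make compound 3 the strongest inhibitor of the three in this cell assay, whereas lengthening the chain on the carbonyl side alone had done nothing that could be told from scatter. No measurement at hand bears on the cause of this shift.

The change removes the carbonyl and exchanges the piperidine ring for a methylpiperazine ring in a single move, and these compounds cannot say which of the two carries the step. A plain 2-(piperidin-1-yl)ethyl group, with the carbonyl gone and the piperidine kept, would separate them, as would a 4-methylpiperazin-1-yl ring on the original carbonyl chain.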